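A Methyl for Bromo at the Assay Limit

A few compounds are considered here, and "the series" means these few. Any claim that something is new, unique, unknown or untested is made for them only; others in the source may bear on it.

In a functional assay on MCF cells (Homo sapiens) for antiproliferative activity, with a stated time of 72 h (on this read-out higher numbers stand for weaker inhibition and lower numbers for stronger inhibition), compound 1 `OC[C@H]1O[C@@H](n2cnc3c(NCc4ccc(F)cc4)ncnc32)[C@H](O)[C@@H]1O` gives 21000 nM. Compound 2 `OC[C@H]1O[C@@H](n2cnc3c(NCc4ccc(Cl)cc4)ncnc32)[C@H](O)[C@@H]1O` returns only a limit, > 166000 nM. Compound 3 `OC[C@H]1O[C@@H](n2cnc3c(NCc4cccc(Br)c4)ncnc32)[C@H](O)[C@@H]1O` also returns only a limit, > 166000 nM. Compound 3 therefore stands at the limit of > 166000 nM in this assay, at which 2 of the 3 values shown sit, with no number of its own.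

Compound 4 `Cc1cccc(CNc2ncnc3c2ncn3[C@@H]2O[C@H](CO)[C@@H](O)[C@H]2O)c1` has not yet been measured. Its structure departs from that of compound 3 by methyl in place of bromo on an aromatic carbon, with methyl in place of bromo on an aromatic carbon, meta to a large group.

Among the measured compounds shown here, no measured step makes this exchange. The closest are an at least 7.9-fold higher number from compound 1 to compound 2 (0.89 log units; beyond the scatter) and an at least 7.9-fold higher number from compound 1 to compound 3 (0.89 log units; beyond the scatter), each beyond the scatter, alongside a step that the two limits leave unreadable from compound 2 to compound 3. Among the three measured compounds, only compound 1 gives a number, at 21000 nM. In this assay, for the measured compounds named here, compound 4 is therefore expected to stay close to the limit, with any shift running towards lower numbers and no large step anticipated. The estimated change is an at least 1.2-fold lower number from compound 3 to compound 4 (0.10 log units; that floor lies within the scatter). The estimate for compound 4 is 130000 nM, with an expected range of 30000 nM to 300000 nM.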

Compound 4, half-maximal inhibitory concentration: > 166000 nM
Compound 4: a limit, no number (the forecaster's own chance of this, stated with the estimate: 60%); middle value at least 1.2-fold (0.10 log units) from the limit.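

In this assay compound 4 returns only a limit, so methyl in place of bromo, on an aromatic carbon meta to a large group, yields no number of its own and adds a third compound to this ceiling: the limit of > 166000 nM in this assay, at which 3 of the 4 values shown sit. The steps among compound 2, compound 3 and compound 4 join limit to limit and cannot be read. Among the compounds shown here, the exchange of 4-fluorophenyl for 3-methylphenyl gives an at least 7.9-fold higher number from compound 1 to compound 4 (0.89 log units; beyond the scatter), which shows that a carbon substituent, and not only chloro or bromo, leaves the series at the limit, with compound 1 still the only one with a number.

Going by these compounds, whether bromo and methyl differ at all stays open, since neither compound gives a number. Also open, on these data alone, is whether 3-fluorophenyl or an aminomethyl group at this position would give a number.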